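This account rests on a few compounds, and the source may have more. Where it says the series, first, only, none or still open, it means among the compounds named here.

Working notes on the series. Within the data shown here, in an assay on isolated protein for inhibition of protein kinase C theta type (Homo sapiens), read by TR-FRET, with a stated time of 2 h (on this read-out higher numbers stand for weaker inhibition and lower numbers for stronger inhibition), compound 3 `CC1(C)C[C@H](Nc2cc(NCc3cnccc3C(F)(F)F)ncc2C#N)CC[C@H]1O` gives 100 nM, the highest of the three numbers so far. Compound 1 `N#Cc1cnc(NCc2cnccc2C(F)(F)F)cc1NC[C@H]1CC[C@@H](O)CC1` gives 58 nM and compound 2 `N#Cc1cnc(NCc2cnccc2C(F)(F)F)cc1NC[C@H]1CC[C@H](O)CC1` gives 50 nM. The steps of a 1.7-fold higher number from compound 1 to compound 3 (0.24 log units; within the scatter) and a 2.0-fold higher number from compound 2 to compound 3 (0.30 log units; within the scatter) both stay within the scatter, so no order among the three is claimed.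

Compound 4 `CC1(C)C[C@@H](Nc2cc(NCc3cnccc3C(F)(F)F)ncc2C#N)CC[C@H]1O` differs from compound 3 only in configuration: the two compounds have the same atoms and bonds and differ only in configuration as drawn: 1 of 2 stereo elements differ; a stereocentre at a saturated ring carbon is drawn R in compound 3 and S in compound 4. Among the measured compounds shown here, the one measured step of a comparable kind is a 1.2-fold lower number from compound 1 to compound 2 (0.06 log units; within the scatter), which rests on the fact that compounds 1 and 2 differ only in the configuration as drawn and lies within the scatter. On that basis a step of a 1.1-fold lower number from compound 3 to compound 4 (0.05 log units; within the scatter) is expected, with no direction beyond the scatter. Compound 4 is therefore estimated at 90 nM, with a range from 35 nM to 250 nM.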

Compound 4, half-maximal inhibitory concentration: 120 nM
For compound 4 the middle estimate is 1.3-fold (0.12 log units) below the measured one; the measured number falls inside the stated range.
By their numbers in this assay, from the lowest: compounds 2, 1, 3 and 4 (each within the scatter of the next, the first and the last beyond it).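

At this saturated ring carbon, inverting one of the two stereocentres gives a 1.2-fold higher number from compound 3 to compound 4 (0.08 log units; within the scatter) in this assay, so no preference for either configuration can be read here: the fact that compounds 3 and 4 differ only in the configuration as drawn

With 4-hydroxy-3,3-dimethylcyclohexyl in place of (4-hydroxycyclohexyl)methyl, the steps now pass beyond the scatter, though modestly: a 2.4-fold higher number from compound 2 to compound 4 (0.38 log units; beyond the scatter) and a 2.1-fold higher number from compound 1 to compound 4 (0.32 log units; beyond the scatter). Compound 3 goes against any general reading, since its steps from the same two compounds stay within the scatter.

The compounds shown do not separate the effect of the two methyl groups from that of the lost methylene link. From the compounds shown here alone, how a carboxylic acid or an amine in place of the hydroxyl would read also remains open.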